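Chloro step from a single clearance value

This account rests on a few compounds, and the source may have more. Where it says the series, first, only, none or still open, it means among the compounds named here.

Among the measured compounds shown here, in an in vitro ADME assay on microsomes from liver (Homo sapiens) for metabolic stability (a lower number here means slower removal, a higher number faster removal of the compound), compound 2 (`c1ccc(C2CCc3nc[nH]c3C2)cc1`) gives 7 mL.min-1.g-1 as the only number so far. For compound 1 (`COc1cccc(C2CCc3nc[nH]c3C2)c1`) the entry reads "not determined" (no result reported) and offers no comparison. Compound 3 (`Clc1cccc(C2CCc3nc[nH]c3C2)c1`) differs from compound 2 by chloro in place of hydrogen on an aromatic carbon. For the measured compounds named here, no measured step speaks to this change. A small rise in this assay is expected, possibly no larger than the scatter. The expected step is a 1.4-fold higher number from compound 2 to compound 3 (0.15 log units; within the scatter) as a working figure. Compound 3 is estimated at 10 mL.min-1.g-1 with an expected range from 4 mL.min-1.g-1 to 22 mL.min-1.g-1 for now.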

Compound 3, intrinsic clearance in microsomes: 21 mL.min-1.g-1
Estimate against measurement, compound 3: 2.1-fold (0.32 log units) below; low and high end bracket the measured number.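

In this assay, among the compounds shown here, chloro in place of hydrogen on an aromatic carbon, meta to a group of 9 heavy atoms, gives a 3.0-fold higher number from compound 2 to compound 3 (0.48 log units; beyond the scatter) as the first readable step. This position therefore responds to a single added chlorine, although one pair cannot define a trend. Nothing on hand accounts for the size of this step. Open, from the compounds shown here alone, is whether a nitrile or a carboxylic acid at this place would move the number in the same direction. Also open, going by these compounds, is whether chloro elsewhere on the six-membered aromatic ring would behave alike.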